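A few compounds are considered here, and "the series" means these few. Any claim that something is new, unique, unknown or untested is made for them only; others in the source may bear on it.

In a functional assay on A-375 cells (Homo sapiens) for antiproliferative activity, read by CCK-8 assay, with a stated time of 72 h (on this read-out higher numbers stand for weaker inhibition and lower numbers for stronger inhibition), compound 1 (`Nc1ccccc1NC(=O)/C=C/c1ccc(CSc2ccc(F)cc2)cc1`) gives 3670 nM. Going by these compounds, compound 2 (`Nc1ccccc1NC(=O)/C=C/c1ccc(CSc2cccc3ccccc23)cc1`) has no single number: its result reads "not determined" (no result reported), so its standing is unknown. Compound 3 (`Nc1ccccc1NC(=O)/C=C/c1ccc(CSCCc2ccccc2)cc1`) carries phenethyl in place of naphthalen-1-yl on a sulfur, (phenethyl in place of naphthalen-1-yl on a sulfur). Among the compounds with values here, no measured step is available to show what such a change does. Within the data shown here, the only anchor is compound 1 at 3670 nM, so in this assay a result for compound 3 no further from that value than the usual scatter is expected. Compound 3 is estimated at 3000 nM, with an expected range of 800 nM to 10000 nM.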

Compound 3, half-maximal inhibitory concentration: 15700 nM
Estimate against measurement, compound 3: 5.2-fold (0.72 log units) below; the whole stated range lies below it.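

In this assay, putting phenethyl in place of 4-fluorophenyl on the sulfur gives a 4.3-fold higher number from compound 1 to compound 3 (0.63 log units; beyond the scatter), so activity at this position does depend on the attached group, and this change weakens it modestly. Compound 2 has no number, so no comparison with its naphthalen-1-yl group can be read. No measurement shown here accounts for the shift. Going by these compounds, the step changes both the chain and the fluorine together, so which one matters stays open. An unsubstituted phenyl or a benzyl group on the sulfur would help separate the two.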